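Series notes: chloro to trifluoromethyl on the shared core

A few compounds are considered here, and "the series" means these few. Any claim that something is new, unique, unknown or untested is made for them only; others in the source may bear on it.

All values below come from an ADME assay on MCF-10A cells (Homo sapiens) for antiproliferative activity, read by sulforhodamine B assay, with a stated time of 48 h; a higher number here means a weaker inhibitor of growth, a lower number a stronger inhibitor of growth.

- compound 1 `Clc1ccc2c(NCCCN3CCCCC3)ccnc2c1`: 47800 nM
- compound 2 `O=C1C(=O)N(CCCNc2ccnc3cc(Cl)ccc23)c2ccccc21`: 35900 nM
- compound 3 `FC(F)(F)c1ccc2c(NCCCN3CCCCC3)ccnc2c1`: 48800 nM

Compound 1 and compound 3 differ in one place only: trifluoromethyl in place of chloro on an aromatic carbon. The step this made in this assay is a 1.0-fold higher number from compound 1 to compound 3 (0.01 log units; within the scatter), so on this core the swap left the number essentially where it was. Compound 2 carries a different group on the chain; the difference between the cores of compound 1 and compound 2 is not broken down here. The values of compound 2 and compound 1 lie within the scatter of each other, as do those of compound 2 and compound 3, so nothing separates the three measured compounds in this assay.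

Compound 4 `O=C1C(=O)N(CCCNc2ccnc3cc(C(F)(F)F)ccc23)c2ccccc21` has not yet been measured. It differs from compound 2 by trifluoromethyl in place of chloro on an aromatic carbon. Among the compounds with values here, this is the same change, at the same place on the shared core, as the one from compound 1 to compound 3; it has been seen once among the measured compounds. Given that single precedent, the expected step in this assay is a 1.0-fold higher number from compound 2 to compound 4 (0.00 log units; within the scatter), to be set beside a 1.0-fold higher number from compound 1 to compound 3 (0.01 log units; within the scatter), and the expectation rests only on that one pair. The one earlier instance sits on a core bearing a different chain substituent, so the carry-over is assumed, not shown. Compound 4 is estimated at 36000 nM in this assay, with a likely span from 18000 nM to 72000 nM.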

Compound 4, concentration for 50% growth inhibition: 46800 nM
Estimate against measurement, compound 4: 1.3-fold (0.11 log units) below; the range from low to high includes it.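

In this assay, trifluoromethyl in place of chloro on the core of compound 2 gives a 1.3-fold higher number from compound 2 to compound 4 (0.12 log units; within the scatter), so on this core too the swap does not separate the two groups. Set beside the earlier instance, the change reads the same on both cores, and the carry-over assumed from a single pair now has a second pair behind it: the same change on two cores in this assay, a 1.0-fold higher number (0.01 log units; within the scatter) from compound 1 to compound 3 and a 1.3-fold higher number (0.12 log units; within the scatter) from compound 2 to compound 4, 1.3-fold (0.11 log units) apart, within the scatter of two such steps

This shows that, on these two cores and in this one assay, the swap left the number within the scatter each time; it does not show that the same would hold on any other core, and with just two pairs, neither of them a step beyond the scatter, it says nothing about how a change that does move the number would carry over.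

Still open, going by these compounds, is whether another group on the same aromatic carbon, such as fluoro, methoxy or nitrile, would give a step beyond the scatter on either core. Also open is how a longer chain, or a carboxylic acid at the end of the chain, would stand in this assay against the four compounds shown.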